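This account rests on a few compounds, and the source may have more. Where it says the series, first, only, none or still open, it means among the compounds named here.

Compound 1 `CCC(C)CCn1nc(-c2cccs2)c(O)c(C2=NS(=O)(=O)c3cc(NS(C)(=O)=O)ccc3N2)c1=O`: > 1 h
Compound 2 `CS(=O)(=O)Nc1ccc2c(c1)S(=O)(=O)N=C(c1c(O)c(-c3cccs3)nn(CCC3CC3)c1=O)N2`: > 1 h
Compound 3 `COC(C)(C)CCn1nc(-c2cccs2)c(O)c(C2=NS(=O)(=O)c3cc(NS(C)(=O)=O)ccc3N2)c1=O`: > 1 h

These three entries are limits of an in vitro ADME assay on microsomes from liver (Homo sapiens) for metabolic stability, tested at 5 uM (a lower number here means that the compound disappears faster, a higher number that the compound lasts longer), not numbers. In this assay compound 3 stands at the limit > 1 h. All the measured compounds share that position: the limit of > 1 h in this assay, at which 3 of the 3 values shown sit.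

Compound 4 `CCCC(C)n1nc(-c2cccs2)c(O)c(C2=NS(=O)(=O)c3cc(NS(C)(=O)=O)ccc3N2)c1=O` differs from compound 3 in the group on an aromatic nitrogen: 1-methylbutyl in place of 3-methoxy-3-methylbutyl on an aromatic nitrogen.

The nearest evidence comes from changes further along the chain: a step that the two limits leave unreadable from compound 1 to compound 2, a step that the two limits leave unreadable from compound 1 to compound 3 and a step that the two limits leave unreadable from compound 2 to compound 3. None of these has a readable size, and none replaces the whole group on the aromatic nitrogen. No step beyond the usual scatter can therefore be expected in either direction.

The expected change is a step that the limit leaves unreadable from compound 3 to compound 4.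

Compound 4 is estimated at 1.3 h, with an expected range from 0.6 h to 3 h.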

Compound 4, half-life: > 1 h
Compound 4 was reported as a limit; the forecaster's own chance of this, stated with the estimate: 65%; the middle value does not contradict the limit.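

Compound 4 also gives a limit rather than a number, so its steps from compound 1, compound 2 and compound 3 cannot be read: the limit of > 1 h in this assay, at which 4 of the 4 values shown sit.

On these data alone, how long each of these four compounds really lasts in this assay, and whether the group on the aromatic nitrogen changes that, stays open.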